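The source may report more compounds than this note shows. Statements on the series, on what has been measured and on what is new or still open speak of the compounds shown alone.

Series notes, alkyl on the aromatic nitrogen of the shared core.

Compound 1 `CCCn1nccc1-c1ccccc1NCC1=NCCN1` carries a propyl on the aromatic nitrogen. In a functional assay with Alpha-1D adrenergic receptor (Homo sapiens) as the target, read by calcium flux (on this read-out lower numbers stand for smaller maximal responses and higher numbers for larger maximal responses), compound 1 gives 0%, so no maximal response is registered. Compound 2 `CC(C)n1nccc1-c1ccccc1NCC1=NCCN1` carries an isopropyl in place of propyl on an aromatic nitrogen. In this assay compound 2 gives 0%. For the measured compounds named here, the one step measured so far, no change at the digits printed from compound 1 to compound 2 (within the scatter), is the only guide to how this position behaves, and it shows that branching the chain at the aromatic nitrogen left the read-out unmoved.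

Compound 2 thus stands level with compound 1 in this assay, both at the floor of the read-out. The next compound, compound 3 `CCn1nccc1-c1ccccc1NCC1=NCCN1`, differs from compound 2 in one place: hydrogen in place of methyl on a saturated chain carbon bound to an aromatic nitrogen and a saturated chain carbon. The same difference, cut one bond further out, reads isopropyl to ethyl.

The step from compound 1 to compound 2 bears on this move, since it also changes only the alkyl on the aromatic nitrogen, and it was flat. For compound 3, therefore, no step beyond the scatter is expected in this assay, a change estimated at no change at the digits printed from compound 2 to compound 3 (within the scatter). Compound 3 is expected to give about 0%, in the range 0% to 10%.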

Compound 3, largest response reached (reported as maximal response), in percent of the reference or control that the assay uses: 0%
Estimate against measurement, compound 3: no gap at the digits printed, and the stated range covers the measured number.
By their numbers in this assay, from the lowest: compounds 1, 2 and 3 (each within the scatter of the next).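

The change from isopropyl to ethyl gives no change at the digits printed from compound 2 to compound 3 (within the scatter) and the hydrogen in place of methyl, two bonds along the chain from the aromatic nitrogen, gives no change at the digits printed from compound 1 to compound 3 (within the scatter) in this assay on the shared core. Ethyl thus joins propyl and isopropyl at this position, so a shorter chain as well as a branched one stays without any registered maximal response, and the flat result no longer rests on a single pair. With all three compounds at the bottom of the read-out, the alkyl makes no visible difference within this set, but a floor offers no means of ranking the three groups.

Going by these compounds, whether any group on the aromatic nitrogen can raise the response stays open; a methyl, a butyl or longer chain, a cyclopropyl, a benzyl, or a chain ending in an amine or a carboxylic acid would test this. On these data alone, it also stays open whether the absent response belongs to the alkyl position at all or to the shared core as a whole.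

No supporting measurement is available to account for the flat read-out at this position.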